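Notes on the series: hydroxymethyl step from compound 2

The source may report more compounds than this note shows. Statements on the series, on what has been measured and on what is new or still open speak of the compounds shown alone.

Of the compounds shown here, two have been measured in a functional assay on the whole organism with Rattus norvegicus as the target; on this read-out higher numbers stand for an effect only at larger amounts of compound and lower numbers for an effect already at smaller amounts. Compound 1 `CCC(C)(C)c1ccc2nc(N)sc2c1` reaches only a limit of the assay, > 10 mg/kg, which is not a number. Compound 2 `Cn1c(=N)sc2cc(OC(F)(F)F)ccc21` gives 5 mg/kg in this assay and is the only compound with a number shown. Of the two values, one sits at a limit: the limit of > 10 mg/kg in this assay, at which 1 of the 2 values shown sits. Compound 3 `N=c1sc2cc(OC(F)(F)F)ccc2n1CCO` differs from compound 2 by hydroxymethyl in place of hydrogen on a saturated chain carbon bound to an aromatic nitrogen. Within the data shown here, no step between two measured compounds is available, so the size of this change rests on the structural difference alone, and no direction is claimed for it. The expected step is a 1.2-fold higher number from compound 2 to compound 3 (0.08 log units; within the scatter), within the usual scatter of this assay. Compound 3 is expected to give 6 mg/kg in this assay, with a range from 2 mg/kg to 15 mg/kg, and a real chance that only a limit is reported.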

Compound 3, dose for half-maximal effect: 8 mg/kg
Compound 3: middle estimate off by 1.3-fold (0.12 log units), on the low side; the range from low to high includes it.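

Among these compounds, the change shows a 1.6-fold higher number from compound 2 to compound 3 (0.20 log units; within the scatter) in this assay and gives the first reading at this position. On a saturated chain carbon bound to an aromatic nitrogen, hydroxymethyl in place of hydrogen therefore leaves the read-out within the scatter, so methyl and 2-hydroxyethyl cannot be put in any order here. Nothing shown bears on a cause for this result.

On these data alone, whether the same holds for other groups at this place stays open: a longer chain, an amine or a carboxylic acid could each read differently from the hydroxyl end of 2-hydroxyethyl. One step on one shared core also leaves open whether the change would read the same way with another group in place of the trifluoromethoxy group.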